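Chloro added to the urea aryl of compound 3

This account rests on a few compounds, and the source may have more. Where it says the series, first, only, none or still open, it means among the compounds named here.

Compound 3, `COc1cc(-c2nn(-c3cccc(NC(=O)Nc4cccc(C(F)(F)F)c4)c3)cc2-c2ccncc2)ccc1Cl`, carries a 3-(trifluoromethyl)phenyl group on the urea nitrogen. In a functional assay on BT-549 cells (Homo sapiens) for inhibition, read by sulforhodamine B assay, with a stated time of 48 h (on this read-out higher numbers stand for lower toxicity in this test and lower numbers for higher toxicity in this test), compound 3 gives 50000 nM, the highest of the two plain numbers in the series. Compound 1, `COc1cc(-c2nn(-c3cccc(NC(=O)Nc4cc(C(F)(F)F)cc(C(F)(F)F)c4)c3)cc2-c2ccncc2)ccc1Cl`, gives 29600 nM in this assay, and a 1.7-fold higher number from compound 1 to compound 3 (0.23 log units; within the scatter). Compound 2, `COc1cc(-c2nn(-c3cccc(NC(=O)Nc4ccc(Cl)c(Cl)c4)c3)cc2-c2ccncc2)ccc1Cl`, is reported in this assay only as a limit, > 50000 nM. For that reason a number no higher from compound 2 to compound 3 (the limit leaves the size open), as indicated by the limit of > 50000 nM in this assay, at which 1 of the 3 values shown sits.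

Compound 4, `COc1cc(-c2nn(-c3cccc(NC(=O)Nc4ccc(Cl)c(C(F)(F)F)c4)c3)cc2-c2ccncc2)ccc1Cl`, differs from compound 3 by chloro in place of hydrogen on an aromatic carbon. Both measured steps bear on this change, since each alters the substituents on the same phenyl ring: removing a trifluoromethyl group left the read-out within the scatter, and exchanging the 3,4-dichlorophenyl for the 3-(trifluoromethyl)phenyl moved it from the limit to a number no higher. Compound 2, with two chlorines on this phenyl, sits at the limit, and compound 1, with two trifluoromethyl groups, sits within the scatter of compound 3. No step beyond the scatter is therefore expected in this assay; a return to the limit is quite possible. Compound 4 is estimated at 45000 nM, with a range of 20000 nM to 100000 nM. The expected step of a 1.1-fold lower number from compound 3 to compound 4 (0.05 log units; within the scatter) is small.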

Compound 4, concentration lethal to 50% of the cells: > 32500 nM
Compound 4 was reported as a limit; the forecaster's own chance of this, stated with the estimate: 45%; the middle value is on the limit's open side.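

In this assay compound 4 gives > 32500 nM, which is a limit. Among these compounds, no step from compound 3 or compound 2 to compound 4 can be read from it. The compounds shown leave open whether chloro in place of hydrogen on the 3-(trifluoromethyl)phenyl of compound 3 shifts the read-out in either direction.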